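The compounds below may be only part of what the source reports. "The series", "measured", "known", "first", "only" and "open" are said of these compounds alone.

Compound 1 `O=C(/C(=C\c1ccc(F)c([N+](=O)[O-])c1)SCc1ccc(F)cc1)c1ccc(F)cc1`: in a physicochemical assay for solubility (on this read-out lower numbers stand for lower solubility and higher numbers for higher solubility), compound 1 gives < 1000 ug/mL, which is a limit of the assay.
Compound 2 `O=C(O)c1ccc(C(=O)/C(=C\c2ccc(F)c([N+](=O)[O-])c2)SCc2ccc(F)cc2)cc1`: in this assay compound 2 gives < 1000 ug/mL, which is a limit of the assay.
Compound 3 `O=C(O)c1ccc(C(=O)/C(=C\c2ccc(O)c(Br)c2)SCc2ccc(Br)cc2)cc1`: in this assay compound 3 gives < 1000 ug/mL, which is a limit of the assay.

Compound 2 therefore stands at a limit in this assay, with no number of its own. Every value in the set is the same: the limit of < 1000 ug/mL in this assay, at which 3 of the 3 values shown sit. Among the measured compounds shown here, the one step between compounds that differ in a single place, a step that the two limits leave unreadable from compound 1 to compound 2, carries carboxy in place of fluoro on an aromatic carbon, and the two limits leave its size unreadable.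

Compound 4 `O=C(O)c1ccc(C(=O)/C(=C\c2ccc(F)c([N+](=O)[O-])c2)SCc2ccccc2)cc1` differs from compound 2 in one place: hydrogen in place of fluoro on an aromatic carbon. For the measured compounds named here, no measured step bears on this change, and the only step recorded cannot be read at all. The expected step that the limit leaves unreadable from compound 2 to compound 4 in this assay is therefore not one that the data can size, and it is expected to stay within the scatter. For compound 4 the estimate in this assay is 200 ug/mL, with a range from 20 ug/mL to 1000 ug/mL, most likely again reported only as a limit.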

Compound 4, solubility: < 1000 ug/mL
Compound 4 was reported as a limit; the forecaster's own chance of this, stated with the estimate: 85%; the middle value does not contradict the limit.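

Compound 2 and compound 4 both sit at a limit, so no step can be read between them in this assay: the limit of < 1000 ug/mL in this assay, at which 4 of the 4 values shown sit.

The compounds shown leave open what number any of them would give in this assay, and so what size either change has.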